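This account rests on a few compounds, and the source may have more. Where it says the series, first, only, none or still open, it means among the compounds named here.

The study measures cytotoxicity in a functional assay on KB cells (Homo sapiens) for cytotoxicity, read by sulforhodamine B assay, with a stated time of 3 days; on this read-out lower numbers stand for stronger inhibition and higher numbers for weaker inhibition. Compound 1, `C=C1C[C@]2(C(=O)O)C[C@H]1CC[C@H]2[C@]1(C)CCC[C@@](C)(C(=O)OC)[C@H]1C(=O)O`, reaches only the limit of the assay and gives no number; its result is recorded as > 10000 nM. Among the compounds with values here, compound 2, `C=CCCC#CC#CC#CCCCCCCCC(=O)O`, is the only compound with a measured number: in this assay compound 2 gives 10000 nM, which is the sole figure in the set. The one further result, that of compound 1, is a limit: the limit of > 10000 nM in this assay, at which 1 of the 2 values shown sits. Compound 3, `CCCCC#CC#CC#CCCCCCCCC(=O)O`, has not yet been measured in this assay. It differs from compound 2 in one place: ethyl in place of vinyl on a saturated chain carbon, two bonds along the chain from a triple-bonded carbon. Within the data shown here, no measured step between two compounds is available, so the size of this change can only be judged from the weak activity of compound 2. The change is small and remote from the acid, so no shift beyond the usual scatter is expected, giving an expected step of no change at the digits printed from compound 2 to compound 3 (within the scatter). Compound 3 is accordingly estimated at 10000 nM, within a range from 4000 nM to 30000 nM.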

Compound 3, half-maximal inhibitory concentration: 10000 nM
Compound 3: the middle estimate sits on the measured number at the digits printed; low and high end bracket the measured number.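

Within the data shown here, the pair gives the first readable step in this assay: ethyl in place of vinyl on a saturated chain carbon, two bonds along the chain from a triple-bonded carbon, gives no change at the digits printed from compound 2 to compound 3 (within the scatter). At this position, then, the double bond of the vinyl group is not needed to keep this weak level of activity. Compound 1 stays a limit and not a number, and it differs from the other two in more than one place, so it adds no step: the limit of > 10000 nM in this assay, at which 1 of the 3 values shown sits.

The compounds shown leave open whether a longer chain, a hydroxyl group or an amine at this position would move the value beyond the scatter. They also leave open what a methyl ester in place of the carboxylic acid would do.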